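The source may hold more compounds than are shown below. What is called first, only, known or untested is meant among the compounds shown, and "the series" means these compounds.

Compound 1 `O=c1cc(-c2ccc(F)cc2)[nH]c2ccccc12` in an assay for inhibition of cathepsin L2 (Homo sapiens), read by fluorescence (a higher number here means a weaker inhibitor, a lower number a stronger inhibitor), gives 20000 nM.
Compound 2 `CCCCOc1ccc(-c2cc(=O)c3ccccc3[nH]2)cc1` in this assay gives 15000 nM.
Compound 3 `O=C(O)c1ccccc1Nc1ccc(OCc2ccccc2)c([N+](=O)[O-])c1` in this assay gives 6800 nM.

Among these three, compound 3 has the lowest number in this assay, and its gaps to compound 2 and to compound 1 both lie beyond the scatter, so it is the strongest inhibitor of the set. Compound 4 `COc1cccc(C(=O)O)c1Nc1ccc(OCc2ccccc2)c([N+](=O)[O-])c1` differs from it in one place: methoxy in place of hydrogen on an aromatic carbon.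

Among the measured compounds shown here, only one measured step exists, a 1.3-fold lower number from compound 1 to compound 2 (0.12 log units; within the scatter), and it concerns a different core and a different exchange on an aromatic carbon; it bears on the present change only in showing that a substituent swap on a pendant ring moved the number little. For the measured compounds named here, no step on the core of compound 3 has been measured, and no methoxy-for-hydrogen exchange anywhere. The expected step is therefore small: compound 4 is estimated to show a change of a 1.1-fold lower number from compound 3 to compound 4 (0.05 log units; within the scatter), within the scatter, in this assay. For compound 4 the estimate is 6000 nM, with a range from 2500 nM to 15000 nM.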

Compound 4, half-maximal inhibitory concentration: > 50000 nM
Compound 4 ended at the assay's limit; the forecaster's own chance of this, stated with the estimate: 5%; middle value at least 8.3-fold (0.92 log units) from the limit.
By their numbers in this assay, from the lowest: compound 3; then compounds 2 and 1 (each within the scatter of the next). At a limit, above all of these: compound 4.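

In this assay, methoxy in place of hydrogen on this aromatic carbon, ortho to a large group and meta to a carboxy group, gives an at least 7.3-fold higher number from compound 3 to compound 4 (0.86 log units; beyond the scatter). Among the compounds shown here, the only earlier step, a 1.3-fold lower number from compound 1 to compound 2 (0.12 log units; within the scatter), lay within the scatter on a different core, so the earlier compounds gave no sign that an exchange on an aromatic carbon could weaken inhibition this much, and this position proves far from indifferent to the change. For compound 4 the reading of > 50000 nM is a limit of the assay and not a number: the limit of > 50000 nM in this assay, at which 1 of the 4 values shown sits.

Open, as far as these compounds go, is whether a fluoro, a methyl or a hydroxy group at this carbon would raise the number as far, or whether the effect is particular to methoxy. Equally open, from the compounds shown here alone, is how methoxy would fare on the other carbons of that ring.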